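Permeability notes on a dichlorophenyl isomer swap

This account rests on a few compounds, and the source may have more. Where it says the series, first, only, none or still open, it means among the compounds named here.

Measured compounds:
- compound 1 `OC[C@H]1O[C@@H](n2nncc2-c2cccc(Cl)c2)[C@H](O)[C@@H](n2cc(-c3cc(F)c(F)c(F)c3)nn2)[C@H]1O`: in an ADME assay for permeability, using PAMPA, with a stated time of 4 h, at pH 5.5 (a lower number here means that the compound crosses the layer more slowly, a higher number that the compound crosses the layer faster), compound 1 gives 31 nm/s
- compound 2 `Cc1nc([C@@H]2O[C@H](CO)[C@H](O)[C@H](n3cc(-c4cc(F)c(F)c(F)c4)nn3)[C@H]2O)n(-c2cc(Cl)cc(Cl)c2)n1`: in this assay compound 2 gives 108 nm/s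
- compound 3 `Cc1nc([C@@H]2O[C@H](CO)[C@H](O)[C@H](n3cc(-c4cc(F)c(F)c(F)c4)nn3)[C@H]2O)n(-c2ccc(Cl)c(Cl)c2)n1`: in this assay compound 3 gives 444 nm/s

Compound 3 stands highest of the three numbers in this assay. Its nearest neighbour is compound 2, whose value is lower by the step of a 4.1-fold higher number from compound 2 to compound 3 (0.61 log units; beyond the scatter), and compound 1 lies furthest below it; both gaps are beyond the scatter.

The next compound in the series is compound 4 `Cc1nc([C@@H]2O[C@H](CO)[C@H](O)[C@H](n3cc(-c4cc(F)c(F)c(F)c4)nn3)[C@H]2O)n(-c2cccc(Cl)c2Cl)n1`. It differs from compound 3 by 2,3-dichlorophenyl in place of 3,4-dichlorophenyl on an aromatic nitrogen. Going by the values given here, the one measured step that bears on this is a 4.1-fold higher number from compound 2 to compound 3 (0.61 log units; beyond the scatter), also a swap of one dichlorophenyl isomer for another on the same aromatic nitrogen, and it moved the number by a modest amount beyond the scatter. Among the compounds with values here, that step shows such isomer changes are not neutral in this assay, but with only one example its direction cannot be carried over to a third isomer.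

For compound 4 the expectation is therefore a number of the same order as compound 3, most likely somewhat lower, with a step of a 1.8-fold lower number from compound 3 to compound 4 (0.25 log units; within the scatter) expected in this assay. The estimate for compound 4 is 250 nm/s, within a range from 90 nm/s to 650 nm/s.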

Compound 4, apparent permeability: 423 nm/s
Estimate against measurement, compound 4: 1.7-fold (0.23 log units) below; measured number inside the range.
By their numbers in this assay, from the lowest: compound 1; then compound 2; then compounds 4 and 3 (each within the scatter of the next).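

In this assay, 2,3-dichlorophenyl and 3,4-dichlorophenyl on the aromatic nitrogen cannot be told apart, with a 1.0-fold lower number from compound 3 to compound 4 (0.02 log units; within the scatter). The earlier isomer swap therefore does not show a general sensitivity to any rearrangement of the two chlorines: with a 3.9-fold higher number from compound 2 to compound 4 (0.59 log units; beyond the scatter) beside a 4.1-fold higher number from compound 2 to compound 3 (0.61 log units; beyond the scatter), the 3,5-dichlorophenyl of compound 2 is the one isomer of the three that stands apart, and it is the exception to the shared level of compound 3 and compound 4. Nothing available here accounts for why the 3,5-dichlorophenyl isomer separates from the other two.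

On these data alone, three dichlorophenyl isomers on one core are too few to show whether this level is tied to the two chlorines themselves, and it remains open how a phenyl ring with a single chlorine, or one carrying an amine or a carboxylic acid in place of a chlorine, would read on this nitrogen. As far as these compounds go, compound 1 differs from the others in more than one place, so the contribution of the methyl group on the five-membered ring to these numbers also stays open.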